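Amide aryl variation in the antiproliferative series

A few compounds are considered here, and "the series" means these few. Any claim that something is new, unique, unknown or untested is made for them only; others in the source may bear on it.

Measured values in a functional assay on GTL 16 cells for antiproliferative activity against GTL 16 cell line (Homo sapiens), read by CCK-8 assay, with a stated time of 72 h; on this read-out higher numbers stand for weaker inhibition and lower numbers for stronger inhibition:
compound 1 `O=C(Nc1cccc(-c2oc3cc(-c4ccc(F)cc4)ccc3c(=O)c2O)c1)c1ccccc1F`: 17400 nM
compound 2 `Cc1ccccc1C(=O)Nc1cccc(-c2oc3cc(-c4ccc(F)cc4)ccc3c(=O)c2O)c1`: 24800 nM
compound 3 `COc1cccc(C(=O)Nc2cccc(-c3oc4cc(-c5ccc(F)cc5)ccc4c(=O)c3O)c2)c1`: 12500 nM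

Compound 3 shows the lowest of the three numbers, yet both distances to it are small: a 1.4-fold lower number from compound 1 to compound 3 (0.14 log units; within the scatter) and a 2.0-fold lower number from compound 2 to compound 3 (0.30 log units; within the scatter), so the three compounds cannot be separated on this read-out. Compound 4 `Cc1cc(C(=O)Nc2cccc(-c3oc4cc(-c5ccc(F)cc5)ccc4c(=O)c3O)c2)ccc1F` is the next entry; the change from compound 3 is 4-fluoro-3-methylphenyl in place of 3-methoxyphenyl on a carbonyl carbon.

Three earlier steps bear on this change. Two of them swap the aryl group on the same carbonyl carbon, a 1.4-fold lower number from compound 1 to compound 3 (0.14 log units; within the scatter) and a 2.0-fold lower number from compound 2 to compound 3 (0.30 log units; within the scatter), and both stay within the scatter. The third, a 1.4-fold higher number from compound 1 to compound 2 (0.15 log units; within the scatter), puts methyl in place of fluoro on an aromatic carbon and also stays within the scatter. Within the data shown here, the entering 4-fluoro-3-methylphenyl group combines the fluoro and methyl substitutions already sampled, and no step so far has moved the number beyond the scatter.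

Compound 4 is therefore expected to sit close to compound 3, with a 1.2-fold higher number from compound 3 to compound 4 (0.08 log units; within the scatter); the estimate for compound 4 in this assay is 15000 nM, range 6000 nM to 40000 nM.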

Compound 4, half-maximal inhibitory concentration: 12100 nM
Compound 4: middle estimate off by 1.2-fold (0.09 log units), on the high side, within the range that was stated.
By their numbers in this assay, from the lowest: compounds 4, 3, 1 and 2 (each within the scatter of the next, the first and the last beyond it).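

At the aryl group on the carbonyl carbon, in this assay, replacing 3-methoxyphenyl, which carries a hydrogen-bond acceptor, with 4-fluoro-3-methylphenyl, which carries none, leaves the read-out unresolved (a 1.0-fold lower number from compound 3 to compound 4 (0.01 log units; within the scatter)). Among these compounds, the same entering group gives the only step in this set printed as beyond the scatter, and that step is modest (a 2.0-fold lower number from compound 2 to compound 4 (0.31 log units; beyond the scatter)), whereas the remaining step stays within it (a 1.4-fold lower number from compound 1 to compound 4 (0.16 log units; within the scatter)), so compound 4 cannot be separated from compound 1 or compound 3. No supporting measurement is available to account for any of these steps.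

On these data alone, all four amide aryl groups are substituted phenyl rings, so it remains open how a carboxylic acid or an aminomethyl group on that ring, or a piperidine in its place, would read. Also open, as far as these compounds go, is whether this narrow spread would hold with a group other than 4-fluorophenyl on the shared core.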